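A few compounds are considered here, and "the series" means these few. Any claim that something is new, unique, unknown or untested is made for them only; others in the source may bear on it.

Measured so far in a functional assay on NCI-H1975 cells (Homo sapiens) for antiproliferative activity, read by CCK-8 assay, with a stated time of 72 h; a higher number here means a weaker inhibitor of growth, a lower number a stronger inhibitor of growth:
compound 1, `CCC1C(=O)N(C)c2cnc(-n3ccc4cc(C(=O)NC(C)C)ccc43)nc2N1c1ccn(C)n1`, gives 12200 nM;
compound 2, `CCC1C(=O)N(C)c2cnc(-n3ccc4cc(C(=O)NC)ccc43)nc2N1c1ccn(C)n1`, gives 35700 nM;
compound 3, `CC[C@@H]1C(=O)N(C)c2cnc(-n3ccc4cc(C(=O)NC)ccc43)nc2N1C1CCCC1`, gives 1370 nM.

In this assay compound 3 is the strongest growth inhibitor of the three, since its steps to both others lie beyond the scatter. The core shared by compound 1 and compound 2 differs from the core of compound 3, and that difference is not broken down here. Between compound 2 and compound 1 a single change was made, (isopropyl in place of methyl on an amide-type nitrogen), and it produced a 2.9-fold lower number from compound 2 to compound 1 (0.47 log units; beyond the scatter). Compound 4, `CC[C@@H]1C(=O)N(C)c2cnc(-n3ccc4cc(C(=O)NC(C)C)ccc43)nc2N1C1CCCC1`, is not yet measured; it carries the same change on the core of compound 3, (isopropyl in place of methyl on an amide-type nitrogen). The place of the change reads the same in both pairs. Because the earlier step of a 2.9-fold lower number from compound 2 to compound 1 (0.47 log units; beyond the scatter) was modest yet beyond the scatter, compound 4 is expected to show a step of similar size, a 2.7-fold lower number from compound 3 to compound 4 (0.44 log units; beyond the scatter). Compound 4 is therefore estimated at 500 nM, with a likely range from 200 nM to 1200 nM.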

Compound 4, concentration for 50% growth inhibition: 1840 nM
Beside the measured number, compound 4's estimate is 3.7-fold (0.57 log units) below it, and the stated range ends below it.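

In this assay, the core of compound 3 gives a different picture from the earlier pair: isopropyl in place of methyl on the amide-type nitrogen gives a 1.3-fold higher number from compound 3 to compound 4 (0.13 log units; within the scatter), so these two compounds cannot be told apart. The change therefore does not carry over with the same result from one core to the other: the same change on two cores in this assay, a 2.9-fold lower number (0.47 log units; beyond the scatter) from compound 2 to compound 1 and a 1.3-fold higher number (0.13 log units; within the scatter) from compound 3 to compound 4, 3.9-fold (0.59 log units) apart, beyond the scatter of two such steps. This shows that the outcome of this change depended on the core in these two pairs, but two pairs give no general rule and do not show which difference between the cores matters.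

Still open, as far as these compounds go, is what an ethyl group, or a longer chain ending in an amine, would do in the same place on either core.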